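Methylsulfonyl for methyl on the benzylidene aryl ring

The source may hold more compounds than are shown below. What is called first, only, known or untested is meant among the compounds shown, and "the series" means these compounds.

The series rests on a shared core, seen in compound 1 `CN(CC1CCC/C(=C\c2ccccc2)C1=O)c1ccccc1`, and is followed in a functional assay on the whole organism (strain Wistar) for inhibition, with Rattus norvegicus as the target, read by paw edema, with stated times of 1 h and 3 h, at a dose of 200 mg/kg by the oral route; on this read-out lower numbers stand for less inhibition and higher numbers for more inhibition at the one dose given (going by the name of the read-out). Compound 1 gives 76.6%. Among the measured compounds shown here, compound 2 `Cc1ccc(/C=C2\CCCC(CN(C)c3ccccc3)C2=O)cc1` gives 44.7%, which is the lowest of the two numbers so far; the only measured step, a number 31.9 percentage points lower from compound 1 to compound 2 (beyond the scatter), is beyond the scatter and is the single piece of evidence on substitution at this aromatic carbon.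

Compound 3 `CN(CC1CCC/C(=C\c2ccc(S(C)(=O)=O)cc2)C1=O)c1ccccc1` differs from compound 2 by methylsulfonyl in place of methyl on an aromatic carbon. For the measured compounds named here, no measured step covers a methylsulfonyl group, so the step from compound 1 to compound 2 bears on it only indirectly, in that a group placed on this aromatic carbon lowered inhibition by a large margin. Methylsulfonyl is a different group from methyl, and the data give no ground to expect it to behave the same way.

The expectation for compound 3 is therefore an uncertain one, set near the present values: a step of a number 5.3 percentage points higher from compound 2 to compound 3 (within the scatter) is estimated, with a wide range. Compound 3 is expected to give about 50% in this assay, between 25% and 75%.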

Compound 3, a percentage reported as inhibition, in the whole organism at one dose (the size of the read-out at that dose, not a potency): 51.1%
Beside the measured number, compound 3's estimate is 1.1 percentage points below it; measured number inside the range.
By their numbers in this assay, from the lowest: compounds 2 and 3 (each within the scatter of the next); then compound 1.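

In this assay, a number 25.5 percentage points lower from compound 1 to compound 3 (beyond the scatter) shows that the loss of inhibition seen with methyl on this aromatic carbon is not confined to methyl, as a second group in place of hydrogen also gives a number beyond the scatter of the hydrogen compound. The exchange of the two groups gives a number 6.4 percentage points higher from compound 2 to compound 3 (within the scatter), so methyl and methylsulfonyl cannot be told apart here, even though methylsulfonyl enters with 4 heavy atoms and 2 hydrogen-bond acceptors where methyl has 1 heavy atom and 0 hydrogen-bond acceptors. Nothing measured on these compounds accounts for this result or for the gap to hydrogen.

On these data alone, whether an amine, a carboxylic acid or a methoxy group on this aromatic carbon would fall with methyl and methylsulfonyl or would stay closer to compound 1 remains open. Also open, as far as these compounds go, is whether the same groups would give the same picture on another carbon of this ring, or at doses other than the single one used in this assay.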